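A few compounds are considered here, and "the series" means these few. Any claim that something is new, unique, unknown or untested is made for them only; others in the source may bear on it.

Compounds measured so far:

compound 1, `O=C1C(=O)N(CN2CCN(c3ccnc4cc(Cl)ccc34)CC2)c2cc(Cl)ccc21` — 36600 nM
compound 2, `O=C1C(=O)N(CN2CCN(c3ccnc4cc(Cl)ccc34)CC2)c2cc(Br)ccc21` — 35800 nM
compound 3, `O=C1C(=O)N(CN2CCN(c3ccnc4cc(C(F)(F)F)ccc34)CC2)c2cccc(Cl)c21` — 28400 nM

All three were tested in a functional assay on MDA-MB-468 cells (Homo sapiens) for cytotoxicity, read by sulforhodamine B assay, with a stated time of 48 h; on this read-out lower numbers stand for stronger inhibition of growth and higher numbers for weaker inhibition of growth. Compound 1 gives 36600 nM in this assay. Compound 2 differs from compound 1 only by bromo in place of chloro on an aromatic carbon. In this assay compound 2 gives 35800 nM, a step of a 1.0-fold lower number from compound 1 to compound 2 (0.01 log units; within the scatter). Compound 3 rests on a different core, and the difference between the two cores is not broken down here. In this assay compound 3 gives 28400 nM, which lies within the scatter of the values of compound 1 and compound 2, so no ordering among the three can be read from these numbers.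

Compound 4, `O=C1C(=O)N(CN2CCN(c3ccnc4cc(C(F)(F)F)ccc34)CC2)c2cccc(Br)c21`, has not yet been measured. It differs from compound 3 by bromo in place of chloro on an aromatic carbon. Among the measured compounds shown here, this is the same kind of change as the one from compound 1 to compound 2, but not the same: in the earlier pair the site was meta to a fused ring and para to a fused ring, whereas here it is ortho to a fused ring and meta to a fused ring. Since the measured step of a 1.0-fold lower number from compound 1 to compound 2 (0.01 log units; within the scatter) stayed within the scatter, the step from compound 3 to compound 4 is expected to be of similar size, a 1.1-fold lower number from compound 3 to compound 4 (0.02 log units; within the scatter). Compound 4 is accordingly estimated to give about 27000 nM in this assay, most likely between 14000 nM and 55000 nM.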

Compound 4, concentration for 50% growth inhibition: 52200 nM
Beside the measured number, compound 4's estimate is 1.9-fold (0.29 log units) below it; the measured number falls inside the stated range.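

In this assay, bromo in place of chloro on an aromatic carbon gives a 1.8-fold higher number from compound 3 to compound 4 (0.26 log units; within the scatter), and setting this beside the earlier pair shows how the change behaves on the two cores: the same change on two cores in this assay, a 1.0-fold lower number (0.01 log units; within the scatter) from compound 1 to compound 2 and a 1.8-fold higher number (0.26 log units; within the scatter) from compound 3 to compound 4, 1.9-fold (0.27 log units) apart, within the scatter of two such steps. In both pairs the exchange of one halogen for the other therefore stays within the usual scatter of this read-out, and the size of the step cannot be told apart between the core of compound 1 and the core of compound 3. Among the compounds shown here, this does not show that the change is without any effect or that it would behave alike on further cores, since only two pairs are available and they differ in the site of the halogen as well as in the core, so any influence of core cannot be separated from one of site.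

The compounds shown carry only chloro or bromo at the exchanged site, which leaves open whether fluoro, a methoxy group, an amine or a carboxylic acid there would give a step beyond the scatter. From the compounds shown here alone, it also remains open whether a longer chain in place of the link to the piperazine would move the growth inhibition any further from these values.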